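Fluorine on the pendant aryl ring of the dioxane series

This account rests on a few compounds, and the source may have more. Where it says the series, first, only, none or still open, it means among the compounds named here.

Compound 1 `CC(C)(Oc1ccccc1)C1OCC(C/C=C\CCC(=O)O)C(c2cccnc2)O1` gives 52 nM in an assay for inhibition of Thromboxane-A synthase (Homo sapiens), using microsomes; a higher number here means a weaker inhibitor, a lower number a stronger inhibitor. Compound 2 `CC(C)(Oc1ccc(F)cc1)C1OCC(C/C=C\CCC(=O)O)C(c2cccnc2)O1` carries fluoro in place of hydrogen on an aromatic carbon and gives 51 nM; the step of a 1.0-fold lower number from compound 1 to compound 2 (0.01 log units; within the scatter) is flat. Compound 3 `CC(C)(Cc1ccccc1)C1OCC(C/C=C\CCC(=O)O)C(c2cccnc2)O1` differs from compound 1 by benzyl in place of phenoxy on a saturated chain carbon bound to two saturated chain carbons and a saturated ring carbon. In this assay compound 3 gives 12 nM; the step of a 4.3-fold lower number from compound 1 to compound 3 (0.64 log units; beyond the scatter) and the step of a 4.3-fold lower number from compound 2 to compound 3 (0.63 log units; beyond the scatter) place compound 3 with the lowest number of the three. Compound 4 `CC(C)(Cc1ccc(F)cc1)C1OCC(C/C=C\CCC(=O)O)C(c2cccnc2)O1` is not yet measured; it repeats the change seen between compound 1 and compound 2, now as fluoro in place of hydrogen on an aromatic carbon on the core of compound 3, whose core differs from that of compound 1 by benzyl in place of phenoxy on a saturated chain carbon bound to two saturated chain carbons and a saturated ring carbon. Because a 1.0-fold lower number from compound 1 to compound 2 (0.01 log units; within the scatter) lay within the scatter, the step of no change at the digits printed from compound 3 to compound 4 (within the scatter) is expected to be similarly flat, resting on that single earlier pair. Compound 4 is therefore estimated at 12 nM in this assay, in the range 6 nM to 25 nM.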

Compound 4, half-maximal inhibitory concentration: 45 nM
Estimate against measurement, compound 4: 3.8-fold (0.57 log units) below; measured number outside the range, above it.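

In this assay, fluoro in place of hydrogen on the aromatic ring does not carry over unchanged between these two cores: the same change on two cores in this assay, a 1.0-fold lower number (0.01 log units; within the scatter) from compound 1 to compound 2 and a 3.8-fold higher number (0.57 log units; beyond the scatter) from compound 3 to compound 4, 3.8-fold (0.58 log units) apart, beyond the scatter of two such steps

With fluoro present, the advantage of benzyl over phenoxy no longer shows: a 1.1-fold lower number from compound 2 to compound 4 (0.05 log units; within the scatter) lies within the scatter, as does a 1.2-fold lower number from compound 1 to compound 4 (0.06 log units; within the scatter), while on the benzyl core the change itself gives a 3.8-fold higher number from compound 3 to compound 4 (0.57 log units; beyond the scatter). This rests on one pair per core and does not show why the two cores differ, or how the change would behave on any other core.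

On these data alone, it remains open whether the rise on the benzyl core is particular to fluoro or would also appear with chloro or methoxy at the same place. As far as these compounds go, whether the phenoxy core would stay flat with those groups is also open.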